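Methoxy for Hydroxy on a Chloropropyl Amide Core

A few compounds are considered here, and "the series" means these few. Any claim that something is new, unique, unknown or untested is made for them only; others in the source may bear on it.

The three measured compounds were tested in a functional assay on M21 cells (Homo sapiens) for antiproliferative activity, with a stated time of 48 h; a higher number here means a weaker inhibitor, a lower number a stronger inhibitor.
Compound 1 `CCCCC(O)c1cccc(NC(=O)NC(=O)CCl)c1` gives 4600 nM.
Compound 2 `CCCCC(OC)c1cccc(NC(=O)NC(=O)CCl)c1` gives 4200 nM.
Compound 3 `CCCCC(O)c1cccc(NC(=O)CCCCl)c1` reaches only a limit of the assay, > 100000 nM, not a number.

Compound 1 and compound 2 differ by methyl in place of hydrogen on an oxygen on a saturated carbon, and the step is a 1.1-fold lower number from compound 1 to compound 2 (0.04 log units; within the scatter). The cores of compound 1 and compound 3 differ by 3-chloropropyl in place of ((chloromethyl)carbonyl)amino on a carbonyl carbon, with the step of an at least 21-fold higher number from compound 1 to compound 3 (1.33 log units; beyond the scatter), compound 3 sitting at the limit of > 100000 nM in this assay, at which 1 of the 3 values shown sits. Compound 4 `CCCCC(OC)c1cccc(NC(=O)CCCCl)c1` is not yet measured; it differs from compound 3 by methyl in place of hydrogen on an oxygen on a saturated carbon, the same change, at the same place, as between compound 1 and compound 2. Because the step of a 1.1-fold lower number from compound 1 to compound 2 (0.04 log units; within the scatter) lies within the scatter, compound 4 is expected to stay near the limit, with an expected step that the limit leaves unreadable from compound 3 to compound 4. Compound 4 is estimated at 150000 nM, between 50000 nM and 500000 nM.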

Compound 4, half-maximal inhibitory concentration: > 100000 nM
Compound 4: only a limit was reported (the forecaster's own chance of this, stated with the estimate: 85%); the middle value is on the limit's open side.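

In this assay compound 4 gives > 100000 nM, a limit of the assay and not a number. The step from hydroxy to methoxy on the core of compound 3 therefore cannot be read, so the series does not show whether the result on the core of compound 1, a 1.1-fold lower number from compound 1 to compound 2 (0.04 log units; within the scatter), carries over to this second core. The step in the other direction remains readable, at an at least 23-fold higher number from compound 2 to compound 4 (1.37 log units; beyond the scatter), and it sets the two cores side by side: the same change on two cores in this assay, an at least 21-fold higher number (1.33 log units; beyond the scatter) from compound 1 to compound 3 and an at least 23-fold higher number (1.37 log units; beyond the scatter) from compound 2 to compound 4; the limit leaves it open whether they differ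

The compounds shown leave open what an ethoxy group, a longer chain or an amine in place of the methoxy would do on the core of compound 1. They also leave open how the hydroxy to methoxy change behaves on any further core that gives a number rather than a limit.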